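Methyl on the amide-type nitrogen of compound 2

The source may report more compounds than this note shows. Statements on the series, on what has been measured and on what is new or still open speak of the compounds shown alone.

In an ADME assay on CEM-SS cells (Homo sapiens) for cytotoxicity, read by XTT assay (on this read-out lower numbers stand for higher toxicity in this test and higher numbers for lower toxicity in this test), the measured compounds read as follows.

Compound 1 `O=C(NO)c1cc2ccn(Cc3ccc(F)cc3F)c2cn1` gives > 320000 nM as a limit
Compound 2 `O=C(NO)c1cc2ccn(Cc3ccc(F)cc3)c2cn1` gives 159000 nM as a number
Compound 3 `NC(=O)c1ccc(Cn2ccc3cc(C(=O)NO)ncc32)cc1` gives > 10000 nM as a limit

Within the data shown here, compound 2 stands alone here as the only compound with a true number, the other two values being limits. Compound 4 `CN(O)C(=O)c1cc2ccn(Cc3ccc(F)cc3)c2cn1` carries methyl in place of hydrogen on an amide-type nitrogen. Among the measured compounds shown here, two measured steps touch compound 2, and both fall on an aromatic carbon, not on that nitrogen. One is an at least 2.0-fold lower number from compound 1 to compound 2 (0.30 log units; that floor lies within the scatter) and the other is a step that the limit leaves unreadable from compound 2 to compound 3 as well. Neither gives a measured size for this change, so no shift beyond the scatter is expected in this assay. The expected step is a 1.1-fold higher number from compound 2 to compound 4 (0.05 log units; within the scatter) and no more than an estimate. Compound 4 is expected near 180000 nM with an estimated range of 80000 nM to 400000 nM on this reasoning.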

Compound 4, half-maximal cytotoxic concentration: 200000 nM
The estimate for compound 4 lay 1.1-fold (0.05 log units) below the measured number; low and high end bracket the measured number.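

In this assay, among these compounds, the first readable step on this amide-type nitrogen is a 1.3-fold higher number from compound 2 to compound 4 (0.10 log units; within the scatter) and so does not separate the two compounds. Thus hydroxy(methyl)carbamoyl and hydroxycarbamoyl cannot be told apart in this test, at least on the core of compound 2. No measurement shown offers a reason for this result.

The compounds shown leave open whether ethyl or a longer chain on this nitrogen would read the same. They also leave open whether a carboxylic acid in place of the hydroxycarbamoyl group would do so.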